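The source may report more compounds than this note shows. Statements on the series, on what has been measured and on what is new or still open speak of the compounds shown alone.

Compound 2 `Cc1cn(-c2cc(NC(=O)c3ccc(C)c(Oc4ccccc4)c3)cc(N3CCN(C)CC3)c2)cn1` is the starting point of this step. In an ADME assay on the whole organism (Mus musculus, strain CD1), read by LC-MS, using cassette dosing, with a stated time of 24 h, at a dose of 0.4 mg/kg by the intravenous route (a lower number here means less compound in the circulation, a higher number more compound in the circulation at the dose given), compound 2 gives 384 ng.h/mL, the second highest of the three numbers measured. Compound 1 `Cc1cn(-c2cc(NC(=O)c3ccc(C)c(Oc4ccccc4)c3)cc(C(F)(F)F)c2)cn1` gives 541 ng.h/mL in this assay, and the change a 1.4-fold lower number from compound 1 to compound 2 (0.15 log units; within the scatter) lies within the scatter of the method. Among the compounds with values here, compound 3 `Cc1cn(-c2cc(NC(=O)c3ccc(C)c(C(=O)c4cccc(C#N)c4)c3)cc(N3CCN(C)CC3)c2)cn1` gives 83 ng.h/mL in this assay, and the step of a 4.6-fold lower number from compound 2 to compound 3 (0.67 log units; beyond the scatter) is the only one among the measured compounds that goes beyond the scatter.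

Compound 4 `Cc1cn(-c2cc(CN3CCC[C@H](N)C3)cc(NC(=O)c3ccc(C)c(Oc4ccccc4)c3)c2)cn1` has not yet been measured. It differs from compound 2 in one place: (3-aminopiperidin-1-yl)methyl in place of 4-methylpiperazin-1-yl on an aromatic carbon. Within the data shown here, of the two measured steps, only the one from compound 1 to compound 2 changes this same position, and that step, a 1.4-fold lower number from compound 1 to compound 2 (0.15 log units; within the scatter), stayed within the scatter. The larger step, a 4.6-fold lower number from compound 2 to compound 3 (0.67 log units; beyond the scatter), concerns a different part of the molecule and says nothing direct about the group that is exchanged here. Nothing measured speaks for a large move in either direction. Compound 4 is therefore expected to give a number in this assay close to that of compound 2, with the step of a 1.3-fold lower number from compound 2 to compound 4 (0.11 log units; within the scatter) expected to stay within the scatter. The estimate for compound 4 is 300 ng.h/mL, with a range from 110 ng.h/mL to 800 ng.h/mL.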

Compound 4, area under the concentration-time curve: 1470 ng.h/mL
Estimate against measurement, compound 4: 4.9-fold (0.69 log units) below, and the stated range ends below it.
By their numbers in this assay, from the lowest: compound 3; then compounds 2 and 1 (each within the scatter of the next); then compound 4.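

In this assay this position proves able to move the number: the change to (3-aminopiperidin-1-yl)methyl gives a 3.8-fold higher number from compound 2 to compound 4 (0.58 log units; beyond the scatter), whereas the earlier exchange at the same place, a 1.4-fold lower number from compound 1 to compound 2 (0.15 log units; within the scatter), had shown no such move. The new group also stands clear of trifluoromethyl, with a 2.7-fold higher number from compound 1 to compound 4 (0.43 log units; beyond the scatter), so among the three compounds that carry phenoxy, compound 4 alone separates from the other two, and it does so upward. Nothing at hand gives a measured reason for this rise in the circulating amount.

The two groups differ at once in the methyl link, in the primary amine and in the ring itself, so the compounds shown do not tell which of these goes with the higher number; a (4-methylpiperazin-1-yl)methyl group or a plain piperidin-1-ylmethyl group at this place would begin to separate them. Also open, on these data alone, are what the opposite configuration at the defined stereocentre would give, and whether the same rise would appear with (3-cyanophenyl)carbonyl in place of phenoxy.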